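The compounds below may be only part of what the source reports. "The series", "measured", "known", "first", "only" and "open" are said of these compounds alone.

Measured compounds in a functional assay with 5-hydroxytryptamine receptor 1B (Homo sapiens) as the target, read by radioligand binding and GTPgammaS binding; on this read-out higher numbers stand for larger maximal responses and lower numbers for smaller maximal responses:
compound 1 `FC1(Cc2ccccc2)CCN(CCCc2c[nH]c3ccc(-n4cnnc4)cc23)CC1` gives 67%
compound 2 `FC1(Cc2ccccc2C(F)(F)F)CCN(CCCc2c[nH]c3ccc(-n4cnnc4)cc23)CC1` gives 91%
compound 3 `Fc1cccc(CCC2(F)CCN(CCCc3c[nH]c4ccc(-n5cnnc5)cc34)CC2)c1` gives 88%

Compound 3 stands second highest of the three values. Its nearest neighbour is compound 2, the gap a number 3 percentage points lower from compound 2 to compound 3 (within the scatter) lying within the scatter, while the gap to compound 1, a number 21 percentage points higher from compound 1 to compound 3 (beyond the scatter), lies beyond it.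

Compound 4 `CC(CC1(F)CCN(CCCc2c[nH]c3ccc(-n4cnnc4)cc23)CC1)c1ccccc1` is the next candidate. Its change from compound 3: 1-phenylethyl in place of 3-fluorobenzyl on a saturated chain carbon bound to a saturated ring carbon.

Within the data shown here, two measured steps bear on this change, both altering the group on the saturated chain carbon bound to a saturated ring carbon. The step of a number 21 percentage points higher from compound 1 to compound 3 (beyond the scatter) was modest and beyond the scatter; the step of a number 3 percentage points lower from compound 2 to compound 3 (within the scatter) was within the scatter. Compound 2 and compound 3, each carrying an aryl group on a short chain at that place, reach similar maximal responses, and compound 4 keeps an aryl group on a short chain at the same place. No step beyond the scatter is therefore expected in this assay, with a number 3 percentage points lower from compound 3 to compound 4 (within the scatter) as the expected shift. For compound 4 the estimate is 85%, with a range from 70% to 98%.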

Compound 4, largest response reached (reported as efficacy), in percent of the reference or control that the assay uses: 85%
Compound 4: middle estimate and measured number agree at the digits printed; measured number inside the range.
By their numbers in this assay, from the lowest: compound 1; then compounds 4, 3 and 2 (each within the scatter of the next).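

In this assay, at the saturated chain carbon bound to a saturated ring carbon, 1-phenylethyl, which holds 8 carbon and no fluorine, gives a response level with both fluorine-bearing groups: a number 3 percentage points lower from compound 3 to compound 4 (within the scatter), and a number 6 percentage points lower from compound 2 to compound 4 (within the scatter). Fluorine in this group is therefore not required for the higher response level in this set, with a number 18 percentage points higher from compound 1 to compound 4 (beyond the scatter). No supporting data accompany this result to say why these groups perform alike.

Still open, going by these compounds, is whether the two mirror-image forms of 1-phenylethyl give the same maximal response. On these data alone, it is also open whether this response level holds when this place carries a longer chain, or a group with an amine or a carboxylic acid.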